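This account rests on a few compounds, and the source may have more. Where it says the series, first, only, none or still open, it means among the compounds named here.

Measured compounds:

Compound 1, `N[C@@H](CC(=O)OC[C@H]1O[C@@H](n2cc(F)c(=O)[nH]c2=O)C[C@@H]1O)C(=O)O`: 0.273 h
Compound 2, `CC(C)[C@H](N)C(=O)OC[C@H]1O[C@@H](n2cc(F)c(=O)[nH]c2=O)C[C@@H]1O`: 0.188 h
Compound 3, `N[C@@H](CC(=O)O[C@H]1C[C@H](n2cc(F)c(=O)[nH]c2=O)O[C@@H]1CO)C(=O)O`: 0.535 h

The read-out throughout is an ADME assay on tissue (MIA PaCa-2 cells, Homo sapiens) for pharmacokinetics; a lower number here means that the compound disappears faster, a higher number that the compound lasts longer. Compound 1 and compound 2 share a core and differ only by 1-amino-2-methylpropyl in place of 2-amino-2-carboxyethyl on a carbonyl carbon; the step is a 1.5-fold lower number from compound 1 to compound 2 (0.16 log units; within the scatter). Compound 3 carries the same two side groups on a different core; how the two cores differ is not broken down here. The value of compound 3 against compound 1 stays within the scatter, while against compound 2 the gap is beyond it.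

Compound 4, `CC(C)[C@H](N)C(=O)O[C@H]1C[C@H](n2cc(F)c(=O)[nH]c2=O)O[C@@H]1CO`, is not yet measured. It differs from compound 3 by 1-amino-2-methylpropyl in place of 2-amino-2-carboxyethyl on a carbonyl carbon. The place lines for the two changes read word for word alike, so this is the same change made once more, now on the core of compound 3. Within the data shown here, the expectation for compound 4 in this assay rests on the one earlier instance: because a 1.5-fold lower number from compound 1 to compound 2 (0.16 log units; within the scatter) stayed within the scatter, a step of similar size, a 1.5-fold lower number from compound 3 to compound 4 (0.17 log units; within the scatter), is expected here as well. Compound 4 is estimated at 0.36 h in this assay, between 0.2 h and 0.65 h. The two-core spread between compound 1 and compound 3 is the main uncertainty, as a single prior step gives no sense of how the change depends on the core.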

Compound 4, half-life: 0.203 h
Beside the measured number, compound 4's estimate is 1.8-fold (0.25 log units) above it; the range from low to high includes it.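

In this assay, putting 1-amino-2-methylpropyl in place of 2-amino-2-carboxyethyl on a carbonyl carbon of the core of compound 3 gives a 2.6-fold lower number from compound 3 to compound 4 (0.42 log units; beyond the scatter), a step beyond the scatter, whereas the same change on the core of compound 1 stayed within it. Set side by side, the two steps do not separate, so the core cannot be said to alter the size of this change: the same change on two cores in this assay, a 1.5-fold lower number (0.16 log units; within the scatter) from compound 1 to compound 2 and a 2.6-fold lower number (0.42 log units; beyond the scatter) from compound 3 to compound 4, 1.8-fold (0.26 log units) apart, within the scatter of two such steps. This supports treating the change as broadly carrying over between these two cores, but it does not show that the two steps are equal, and two cores give no basis for a rule covering others in the series.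

The swap alters the whole side group at once, so these compounds leave open whether the carboxylic acid or the branched carbon chain accounts for the step. A plain aminoalkyl chain, or a longer chain carrying the amine, on either core would help separate the two.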